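The source may report more compounds than this note shows. Statements on the series, on what has been measured and on what is new or still open speak of the compounds shown alone.

In a functional assay on NCI-H460 cells (Homo sapiens) for cytotoxicity, read by MTT assay, with a stated time of 48 h (a higher number here means a weaker inhibitor, a lower number a stronger inhibitor), compound 3 (`COc1ccc(/C=C/C(=O)/C=C/c2cc3ccccc3nc2Oc2ccc(Br)cc2)cc1`) gives > 10000 nM, a limit and not a number. Compound 1 (`COc1ccc(/C=C/C(=O)/C=C/c2cc3ccccc3nc2Cl)c(OC)c1`) gives > 10000 nM, also a limit. Compound 2 (`COc1ccc(/C=C/C(=O)/C=C/c2cc3ccccc3nc2Oc2ccccc2)c(OC)c1`) gives > 10000 nM, again a limit. Among the compounds with values here, the series so far stands at the limit of > 10000 nM in this assay, at which 3 of the 3 values shown sit.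

Compound 4 (`COc1ccc(/C=C/C(=O)/C=C/c2cc3ccccc3nc2Oc2ccc(Br)cc2)c(OC)c1`) differs from compound 3 by methoxy in place of hydrogen on an aromatic carbon, 4-methoxyphenyl to 2,4-dimethoxyphenyl. Within the data shown here, the only measured step, a step that the two limits leave unreadable from compound 1 to compound 2, is a different change and offers no size to carry over. No step beyond the scatter is therefore expected in this assay, and another limit is the likeliest report. Compound 4 is expected at 12000 nM, with an estimated range of 5000 nM to 30000 nM.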

Compound 4, half-maximal inhibitory concentration: > 10000 nM
Compound 4 was reported as a limit (the forecaster's own chance of this, stated with the estimate: 75%); the middle value is on the limit's open side.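

The steps from compound 1, compound 2 and compound 3 to compound 4 cannot be read in this assay, since all four compounds are reported only as limits: the limit of > 10000 nM in this assay, at which 4 of the 4 values shown sit.

The compounds shown leave open which change to the shared core, if any, would give a measurable value in this assay.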